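Chloro for Fluoro Across Two Related Series

A few compounds are considered here, and "the series" means these few. Any claim that something is new, unique, unknown or untested is made for them only; others in the source may bear on it.

Compound 1 `O=Cc1cn(Cc2ccc(Cl)cc2)c2ccc(F)cc12` is tested in an ADME assay on T29 cells (Homo sapiens) for cytotoxicity, read by sulforhodamine B assay, with a stated time of 3 days; a lower number here means a stronger inhibitor, a higher number a weaker inhibitor. In this assay compound 1 gives > 31600 nM, which is a limit of the assay and not a number. Compound 2 `O=Cc1cn(Cc2ccc(Cl)cc2)c2ccc(Cl)cc12` differs from compound 1 by chloro in place of fluoro on an aromatic carbon. In this assay compound 2 gives > 31600 nM, again a limit of the assay. The step that the two limits leave unreadable from compound 1 to compound 2 therefore cannot be sized. Compound 3 `OCc1cn(Cc2cccc(F)c2)c2ccccc12` has a different core, and the difference between the two cores is not broken down here. In this assay compound 3 gives > 31600 nM, also a limit of the assay. Compound 4 `OCc1cn(Cc2cccc(Cl)c2)c2ccccc12` differs from compound 3 by chloro in place of fluoro on an aromatic carbon, the same kind of change as that from compound 1 to compound 2, though there the place is part of a fused or bridged system of two rings, meta to a fused ring and para to a fused ring, whereas here it is meta to a large group. Because (the limit of > 31600 nM in this assay, at which 3 of the 3 values shown sit), the step that the limit leaves unreadable from compound 3 to compound 4 is expected to be unreadable as well. Compound 4 is estimated at 45000 nM in this assay, most likely reported only as a limit.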

Compound 4, half-maximal inhibitory concentration: > 31600 nM
Compound 4 ended at the assay's limit; the forecaster's own chance of this, stated with the estimate: 85%; the middle value does not contradict the limit.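

No step can be read between compound 3 and compound 4, which both rest at a limit of this assay: the limit of > 31600 nM in this assay, at which 4 of the 4 values shown sit. The compounds shown leave open how chloro in place of fluoro, or the difference between the cores, bears on the read-out in this assay.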